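Amino for hydroxymethyl: expected effect on cell tolerance

The compounds below may be only part of what the source reports. "The series", "measured", "known", "first", "only" and "open" are said of these compounds alone.

Measured compounds:
Compound 1 `CC(C)CCn1c(Cn2c(=O)n(C(C)C)c3ccccc32)nc2cc(CO)ccc21` in an ADME assay on HEp-2 cells (Homo sapiens) for cytotoxicity (a higher number here means that more compound is tolerated, a lower number that less compound is tolerated), gives 31600 nM.
Compound 2 `CC(C)CCn1c(Cn2c(=O)n(C(C)C)c3ccccc32)nc2ccc(CN(C)C)cc21` in this assay gives 26700 nM.

Within the data shown here, compound 1 holds the higher of the two numbers so far, but the gap to compound 2 lies within the scatter, so the two cannot be told apart on tolerance. Compound 3 `CC(C)CCn1c(Cn2c(=O)n(C(C)C)c3ccccc32)nc2cc(N)ccc21` has not yet been measured. It differs from compound 1 in one place: amino in place of hydroxymethyl on an aromatic carbon. Both the group that leaves and the group that enters carry one hydrogen-bond donor and one acceptor, and neither carries a charge, so the change swaps like for like in those counts. Among the measured compounds shown here, with no measured step of this kind to lean on, the step from compound 1 to compound 3 is expected to be small, a 1.2-fold lower number from compound 1 to compound 3 (0.07 log units; within the scatter), in either direction and likely within the scatter. Compound 3 is therefore estimated at 27000 nM, with a range from 11000 nM to 65000 nM.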

Compound 3, half-maximal cytotoxic concentration: 32200 nM
Compound 3: middle estimate off by 1.2-fold (0.08 log units), on the low side; the range from low to high includes it.
By their numbers in this assay, from the lowest: compounds 2, 1 and 3 (each within the scatter of the next).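

Among these compounds, putting amino in place of hydroxymethyl on this aromatic carbon gives a 1.0-fold higher number from compound 1 to compound 3 (0.01 log units; within the scatter) in this assay, the first direct reading of any change at this position. Across this one swap, tolerance of the cells does not move measurably, so hydroxymethyl is not needed here for the number to stay where it is, and a group with one heavy atom serves as well as one with two. Among the compounds shown here, nothing measured so far explains why the two groups match.
One swap between two small neutral groups says little about how much change this position can absorb, so a carboxylic acid, a dimethylamine or a longer chain on the same carbon could still give a different number. On these data alone, whether amino and hydroxymethyl would also match on another core remains open.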